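One Added Methyl on a Chain at the Limit

The source may report more compounds than this note shows. Statements on the series, on what has been measured and on what is new or still open speak of the compounds shown alone.

Compound 1 `CCCCCCC(CCO)n1cnc2c(NC)ncnc21`: > 50000 nM
Compound 2 `CCCCCCC(CCO)n1cnc2cncnc21`: > 50000 nM

In a functional assay on SW480 cells (Homo sapiens) for antiproliferative activity, read by MTT assay, with a stated time of 48 h (on this read-out lower numbers stand for stronger inhibition and higher numbers for weaker inhibition), compound 1 gives > 50000 nM, which is a limit and not a number. Compound 2 gives > 50000 nM, and this too is a limit. Compound 1 therefore stands at the limit of > 50000 nM in this assay, at which 2 of the 2 values shown sit, and no measured number lies on either side of it.

Compound 3 `CCCCCCCC(CCO)n1cnc2c(NC)ncnc21` departs from compound 1 by one change: methyl in place of hydrogen on a saturated chain carbon, seven bonds along the chain from an aromatic nitrogen. For the measured compounds named here, only one measured step is available, a step that the two limits leave unreadable from compound 1 to compound 2. That step concerns a different change, on an aromatic carbon rather than on the chain, and it offers no size to carry over. Going by the values given here, no measured step shows what the added methyl does, so no clear direction or size of change can be expected in this assay. The expectation is simply that compound 3 stays close to the limit seen for compound 1. The expected step is a number no higher from compound 1 to compound 3 (the limit leaves the size open). For compound 3 the estimated value is 50000 nM, with an expected range from 20000 nM to 100000 nM.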

Compound 3, half-maximal inhibitory concentration: 15300 nM
For compound 3 the middle estimate is 3.3-fold (0.51 log units) above the measured one; measured number below the stated range.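

The added methyl, on a saturated chain carbon seven bonds along the chain from an aromatic nitrogen, gives in this assay an at least 3.2-fold lower number from compound 1 to compound 3 (0.51 log units; beyond the scatter), so this chain position is one where a single added carbon can bring a compound off the limit and onto a measured number. Going by these compounds, the starting point of that step is a limit and not a number, which means the step gives only a smallest size, and the true distance between the two compounds stays unknown. Compound 3 is the only one of the three compounds shown that gives a measured number, while the other two remain at a limit: the limit of > 50000 nM in this assay, at which 2 of the 3 values shown sit.

The step between the two compounds at the limit cannot be read, so the compounds shown do not say what the methylamino group contributes once the chain carries the added methyl. They also leave open whether a still longer chain would carry the change further in the same direction, and what an amine or a carboxylic acid on the chain would do in this assay.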